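The source may report more compounds than this note shows. Statements on the series, on what has been measured and on what is new or still open speak of the compounds shown alone.

Compound 1, `CC(C)n1cc(-c2ccnc3[nH]c(C4CCN(CC(=O)N5CCCCC5)CC4)cc23)ccc1=O`, gives 159 mL/min/kg in an ADME assay (Rattus norvegicus, strain Han-wistar) for pharmacokinetics, at a dose of 1.5 umol/kg by the intravenous route; a higher number here means faster removal of the compound, a lower number slower removal.
Compound 2, `CC(C)n1cc(-c2ccnc3[nH]c(C4CCN(CC(=O)N5CCCC5)CC4)cc23)ccc1=O`, gives 91 mL/min/kg in this assay.
Compound 3, `CC(C)n1cc(-c2ccnc3[nH]c(C4CCN(Cc5cccs5)CC4)cc23)ccc1=O`, gives 92 mL/min/kg in this assay.

Among these three numbers compound 3 stands second highest. Its nearest neighbour is reached by the step of a 1.0-fold higher number from compound 2 to compound 3 (0.00 log units; within the scatter), its furthest by the step of a 1.7-fold lower number from compound 1 to compound 3 (0.24 log units; within the scatter); neither separates compound 3 from the others beyond the scatter.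

Compound 4, `CNC(=O)CN1CCC(c2cc3c(-c4ccc(=O)n(C(C)C)c4)ccnc3[nH]2)CC1`, has not yet been measured in this assay. It differs from compound 3 in one place: methylcarbamoyl in place of thiophen-2-yl on a saturated chain carbon bound to an amine nitrogen in a ring.

Among the measured compounds shown here, two measured steps bear on this change, since each exchanges the group on the saturated chain carbon bound to an amine nitrogen in a ring between a thiophen-2-yl and a carbonyl bearing a ring amine: a 1.7-fold lower number from compound 1 to compound 3 (0.24 log units; within the scatter) and a 1.0-fold higher number from compound 2 to compound 3 (0.00 log units; within the scatter). Both stayed within the scatter. Compound 4 carries a methylcarbamoyl at that position, again a carbonyl-bearing group as in compound 1 and compound 2, so no step beyond the scatter is expected in this assay. Compound 4 is therefore expected to give about 95 mL/min/kg, with a range from 55 mL/min/kg to 170 mL/min/kg. This amounts to an expected step of a 1.0-fold higher number from compound 3 to compound 4 (0.01 log units; within the scatter).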

Compound 4, clearance in the Rattus norvegicus assay: 89 mL/min/kg
Compound 4: middle estimate off by 1.1-fold (0.03 log units), on the high side; measured number inside the range.
By their numbers in the Rattus norvegicus assay, from the lowest: compounds 4, 2, 3 and 1 (each within the scatter of the next).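

In the Rattus norvegicus assay, the methylcarbamoyl on a saturated chain carbon bound to an amine nitrogen in a ring stays within the scatter of the thiophen-2-yl (a 1.0-fold lower number from compound 3 to compound 4 (0.01 log units; within the scatter)) and of both ring amides (a 1.0-fold lower number from compound 2 to compound 4 (0.01 log units; within the scatter); a 1.8-fold lower number from compound 1 to compound 4 (0.25 log units; within the scatter)), so a small open-chain amide with an amide hydrogen fits the same narrow band as the other three groups. The second read-out separates a pair that clearance does not: in a physicochemical assay for lipophilicity, using the shake flask method, measured as octanol-water partition, at pH 7.4 (on this read-out lower numbers stand for lower lipophilicity and higher numbers for higher lipophilicity), compound 3 gives 3.4 and compound 4 gives 2.2. This change therefore moves the distribution coefficient well beyond the scatter while clearance in the Rattus norvegicus assay stays within it for this pair, so for compound 3 and compound 4 clearance does not follow the distribution coefficient: the measured distribution coefficient of compound 3, 3.4, and of compound 4, 2.2, a number 1.20 log units lower (beyond the scatter).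

Going by these compounds, how compound 1 and compound 2 stand on the distribution coefficient stays open, so this reading rests on a single pair. Also open is whether a carboxylic acid, a basic amine or a longer chain at this position would move clearance beyond the scatter, since every group shown here leaves it within the scatter.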